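Cytotoxicity notes on the amide series, compound 3 pending

This account rests on a few compounds, and the source may have more. Where it says the series, first, only, none or still open, it means among the compounds named here.

compound 1 `O=C(Nc1cccc(N2CCCC2=O)c1)C1CCCN(C(=O)c2cc(C(F)(F)F)cc(C(F)(F)F)c2)C1` 0%
compound 2 `CC(=O)Nc1cccc(C(=O)N2CCCC(C(=O)Nc3ccc(Cl)cc3)C2)c1` 4%

In an ADME assay on PC-3 cells (Homo sapiens) for cytotoxicity, read by WST assay, tested at 100 uM (on this read-out higher numbers stand for more inhibition at the one concentration tested (going by the name of the read-out) and lower numbers for less inhibition), compound 1 gives 0% and compound 2 gives 4%; the two numbers lie within the usual scatter of each other. Compound 3 `O=C(Nc1ccc(Cl)cc1)C1CCCN(C(=O)c2cc(C(F)(F)F)cc(C(F)(F)F)c2)C1` keeps the core of compound 1 and differs by 4-chlorophenyl in place of 3-(2-oxopyrrolidin-1-yl)phenyl on an amide-type nitrogen. Among the measured compounds shown here, no step between measured compounds is available, so the size of this change cannot be read from the data. Because compound 1 gives 0%, the step of a number 3 percentage points higher from compound 1 to compound 3 (within the scatter) is expected to stay within the scatter. Compound 3 is estimated at 3%, range 0% to 15%.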

Compound 3, a percentage reported as inhibition, at one concentration (the size of the read-out at that concentration, not a potency): 14%
For compound 3 the middle estimate is 11 percentage points below the measured one, within the range that was stated.
By their numbers in this assay, from the lowest: compounds 1, 2 and 3 (each within the scatter of the next, the first and the last beyond it).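

Putting 4-chlorophenyl in place of 3-(2-oxopyrrolidin-1-yl)phenyl on an amide-type nitrogen gives, in this assay, a number 14 percentage points higher from compound 1 to compound 3 (beyond the scatter). This position can therefore shift the read-out beyond the scatter, though only modestly. No available evidence bears on the reason for this step.

On these data alone, the change swaps the 2-oxopyrrolidin-1-yl group and the chlorine together, and which of the two carries the step stays open. As far as these compounds go, how an unsubstituted phenyl or a 4-aminophenyl on that nitrogen would read also stays open.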